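The compounds below may be only part of what the source reports. "The series", "measured", "known", "first", "only" and "open" are said of these compounds alone.

Compound 1, `COc1ccc(/C=C/C(=O)OC[C@@H](OCc2ccccc2)[C@H]2OC(=O)C=C[C@H]2OCc2ccccc2)cc1`: 1080 nM
Compound 2, `COc1ccc(/C=C/C(=O)OC[C@@H](OC(C)=O)[C@H]2OC(=O)C=C[C@H]2OC(C)=O)cc1`: 5930 nM
Compound 3, `CC(=O)OC[C@@H](OC(C)=O)[C@H]1OC(=O)C=C[C@H]1OC(C)=O`: 2640 nM

Of the compounds shown here, three have been measured in a functional assay on HeLa cells (Homo sapiens) for antiproliferative activity, read by MTT assay, with a stated time of 6 days; a lower number here means a stronger inhibitor, a higher number a weaker inhibitor. Compound 1 gives the lowest number of the three; compound 3 comes nearest to it, and compound 2 stands furthest away with the highest number. Compound 4, `CC(=O)OC[C@@H](OCc1ccccc1)[C@H]1OC(=O)C=C[C@H]1OCc1ccccc1`, has not yet been measured. It differs from compound 1 in a single place: methyl in place of 2-(4-methoxyphenyl)ethenyl on a carbonyl carbon.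

Among the compounds with values here, one measured step bears directly on this change. Compound 2 and compound 3 differ in exactly the same way, the cinnamate-type ester of compound 2 being cut back to the acetyl of compound 3, and that step gave a 2.2-fold lower number from compound 2 to compound 3 (0.35 log units; beyond the scatter). In that pair the remaining groups on the core were acetyl groups; in compound 1 and compound 4 they are benzyl ethers, so the setting is not identical, and a single step is a thin basis.

Taken at face value, the same change is expected to carry over, so that compound 4 is estimated to show a step of a 1.8-fold lower number from compound 1 to compound 4 (0.26 log units; within the scatter). Compound 4 is therefore expected to give about 600 nM in this assay, with a plausible range from 250 nM to 1500 nM.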

Compound 4, half-maximal inhibitory concentration: 5350 nM
Compound 4: the middle estimate sits 8.9-fold (0.95 log units) below what was measured; measured number above the stated range.
By their numbers in this assay, from the lowest: compound 1; then compound 3; then compounds 4 and 2 (each within the scatter of the next).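

In this assay, cutting (2-(4-methoxyphenyl)ethenyl)carbonyl back to acetyl gave a 5.0-fold higher number from compound 1 to compound 4 (0.69 log units; beyond the scatter). This shows that the change has no single direction of its own: on the core carrying benzyl ethers, the 2-(4-methoxyphenyl)ethenyl group goes with the lower number, whereas on the core carrying acetyl groups it goes with the higher one. What this replacement does in this assay therefore depends on the groups held elsewhere on the core, and the step from one pair cannot be carried over to the other: the same change on two cores in this assay, a 2.2-fold lower number (0.35 log units; beyond the scatter) from compound 2 to compound 3 and a 5.0-fold higher number (0.69 log units; beyond the scatter) from compound 1 to compound 4, 11-fold (1.05 log units) apart, beyond the scatter of two such steps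

The compounds shown leave open what a phenyl group or a longer alkyl chain would do in place of the methyl on this carbonyl carbon, and so whether the aromatic ring, the double bond or simply the larger group counts on each core. Within the data shown here, also open is how the same change would read with free hydroxyl groups in place of the benzyl ethers or acetyl groups, as only two settings of the core are available here.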